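A Pyridine Ring Replaces a Fluorophenyl Group

The source may report more compounds than this note shows. Statements on the series, on what has been measured and on what is new or still open speak of the compounds shown alone.

Of the compounds shown here, three have been measured in an assay on CHO cells for displacement of a labelled ligand from 5-hydroxytryptamine receptor 7 (Homo sapiens), read by scintillation counting; a lower number here means a stronger inhibitor, a higher number a weaker inhibitor. Compound 1 `CCC1(CCCCN2CCN(c3ccccc3Cl)CC2)C(=O)Nc2ccccc21` gives 53 nM in this assay. Compound 2 `O=C1Nc2cc(F)ccc2C1CCCCN1CCN(c2ccc(Cl)cc2)CC1` gives 25 nM in this assay. Compound 3 `O=C1Nc2ccccc2C1CCCCN1CCN(c2ccc(F)cc2)CC1` gives 5 nM in this assay, the lowest of the three numbers; compound 2 stands nearest to it and compound 1 furthest, and both of those gaps lie beyond the usual scatter, so compound 3 is the strongest inhibitor among the three measured.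

Compound 4 `O=C1Nc2ccccc2C1CCCCN1CCN(c2ccccn2)CC1` differs from compound 3 in a single place: pyridin-2-yl in place of 4-fluorophenyl on an amine nitrogen in a ring. Among the compounds with values here, the three measured compounds differ from one another at several places at once, so no pair of them isolates a change on this ring, and there is no measured step to lean on. What can be said is that compound 3 already sits at the low end of the numbers seen, which leaves more room for a rise than for a further fall. The step from compound 3 to compound 4 is therefore estimated as a 3.0-fold higher number from compound 3 to compound 4 (0.48 log units; beyond the scatter), a modest weakening that may still fall within the scatter. Compound 4 is expected to give about 15 nM in this assay, with a likely range from 5 nM to 50 nM.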

Compound 4, inhibition constant: 10.9 nM
The estimate for compound 4 lay 1.4-fold (0.14 log units) above the measured number; measured number inside the range.
By their numbers in this assay, from the lowest: compound 3; then compound 4; then compound 2; then compound 1.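

Within the data shown here, the step of a 2.2-fold higher number from compound 3 to compound 4 (0.34 log units; beyond the scatter) in this assay is the first reading of this position, on an amine nitrogen in a ring, since the earlier compounds differ from one another at several places at once. It shows that this position accepts pyridin-2-yl in place of 4-fluorophenyl at a modest cost: the step lies beyond the scatter, yet compound 4 still gives 10.9 nM, with a ring that carries 1 hydrogen-bond acceptor where the leaving ring carries 0. Nothing at hand bears on why the number rises with this change.

Among these compounds, the single step joins two differences, the ring nitrogen entering and the fluorine leaving, and only a plain phenyl group at this position could begin to pull them apart. Also open, on these data alone, are how pyridin-3-yl, pyridin-4-yl or pyrimidin-2-yl would read here, and whether the same step holds on a core that carries an ethyl group or a fluorine.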